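The compounds below may be only part of what the source reports. "The series", "measured", "known", "first", "only" and "open" are said of these compounds alone.

Compound 3 `CCCCCCCCCCc1ccc(-c2noc([C@H]3CCCN3)n2)cc1` stands lowest of the three in an assay on HeLa cells for inhibition of sphingosine-1-phosphate transporter SPNS2 (Mus musculus), read by LC-MS, tested at 2 uM (on this read-out higher numbers stand for more inhibition at the one concentration tested (going by the name of the read-out) and lower numbers for less inhibition), giving 12%. Compound 2 `CCCCCCCCCCc1ccc(-c2noc(CCCNC)n2)cc1` gives 45% and compound 1 `CCCCCCCCCCc1ccc(-c2noc(CCCCN)n2)cc1` gives 55%. Among the measured compounds shown here, two steps bear on the move to compound 4 `CCCCCCCCCCc1ccc(-c2noc(C(Cl)CCN)n2)cc1`: a number 43 percentage points lower from compound 1 to compound 3 (beyond the scatter) and a number 33 percentage points lower from compound 2 to compound 3 (beyond the scatter), both large, whereas a number 10 percentage points lower from compound 1 to compound 2 (within the scatter). The change is a group of 5 heavy atoms (3 carbon, 1 nitrogen, 1 chlorine; no ring) in place of a group of 5 heavy atoms (4 carbon, 1 nitrogen; one five-membered non-aromatic ring with 1 hetero atom), on an aromatic carbon. The entering group, having no ring, is closer in kind to the 4-aminobutyl of compound 1 than to the pyrrolidin-2-yl of compound 3, so part of the loss seen in a number 43 percentage points lower from compound 1 to compound 3 (beyond the scatter) is expected to be regained; the chlorine is new to the series and leaves the size uncertain. Compound 4 is therefore expected to gain, a number 26 percentage points higher from compound 3 to compound 4 (beyond the scatter). For compound 4 the estimate is 38%, range 15% to 62%.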

Compound 4, a percentage reported as inhibition, at one concentration (the size of the read-out at that concentration, not a potency): 5%
Compound 4: the middle estimate sits 33 percentage points above what was measured; measured number outside the range, below it.
By their numbers in this assay, from the lowest: compounds 4 and 3 (each within the scatter of the next); then compounds 2 and 1 (each within the scatter of the next).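

Opening the ring does not by itself restore the number: with the chlorine-bearing open chain in place of pyrrolidin-2-yl, there is a number 7 percentage points lower from compound 3 to compound 4 (within the scatter). Against the other open chains the change is large, with a number 40 percentage points lower from compound 2 to compound 4 (beyond the scatter) and a number 50 percentage points lower from compound 1 to compound 4 (beyond the scatter), so having no ring on this aromatic carbon is not sufficient for a high number. Nothing available explains this result.

Going by these compounds, whether the chlorine alone carries the loss remains open. A 3-aminopropyl chain without chlorine, or one with a hydroxyl in its place, would separate the chlorine from the chain itself.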